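Swapping the ring cap on the piperidine nitrogen

The source may hold more compounds than are shown below. What is called first, only, known or untested is meant among the compounds shown, and "the series" means these compounds.

Measured compounds:
- compound 1, `CCCS(=O)(=O)N1CC=C(c2ccc3c(c2)CC(C2CCN(c4ncc(C(F)(F)F)cn4)CC2)O3)CC1`: 14 nM
- compound 2, `CCCS(=O)(=O)N1CC=C(c2ccc3c(c2)CC(C2CCN(c4ccc(C(F)(F)F)cn4)CC2)O3)CC1`: 34 nM

In a functional assay on HEK293 cells for agonist activity at Glucose-dependent insulinotropic receptor (Homo sapiens), read by cAMP accumulation, with a stated time of 60 min (a lower number here means that less compound is needed, a higher number that more compound is needed for the effect), compound 2 gives 34 nM, the higher of the two numbers; its nearest neighbour is compound 1, and the step of a 2.4-fold higher number from compound 1 to compound 2 (0.39 log units; beyond the scatter) is beyond the scatter. Compound 3, `CCCc1cnc(N2CCC(C3Cc4cc(C5=CCN(S(=O)(=O)CCC)CC5)ccc4O3)CC2)nc1`, carries 5-propylpyrimidin-2-yl in place of 5-(trifluoromethyl)pyridin-2-yl on an amine nitrogen in a ring. For the measured compounds named here, only the step from compound 1 to compound 2 bears on this, and it concerns the ring swap alone; the propyl in place of trifluoromethyl has no measured counterpart here. Running the ring change back is expected to lower the number, so for compound 3 an estimate of 18 nM (5 nM to 65 nM) seems reasonable, a step of a 1.9-fold lower number from compound 2 to compound 3 (0.28 log units; within the scatter).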

Compound 3, half-maximal effective concentration: 82 nM
The estimate for compound 3 lay 4.6-fold (0.66 log units) below the measured number; the whole stated range lies below it.
By their numbers in this assay, from the lowest: compound 1; then compound 2; then compound 3.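

For the compounds shown here, with the pyrimidine ring held constant, propyl in place of trifluoromethyl on an aromatic carbon gives a 5.9-fold higher number from compound 1 to compound 3 (0.77 log units; beyond the scatter) in this assay, the first reading of the group on that carbon. Changing both ring and group gives a 2.4-fold higher number from compound 2 to compound 3 (0.38 log units; beyond the scatter), so a pyrimidine ring alone does not secure the low number of compound 1. No available evidence explains this change. Still open, going by these compounds, is where a methyl, an ethyl or a nitrile on that carbon would fall, and whether propyl on the pyridine ring would give a similar step.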